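This account rests on a few compounds, and the source may have more. Where it says the series, first, only, none or still open, it means among the compounds named here.

Measured compounds in an ADME assay on HepG2 2.2.15 cells (Homo sapiens) for cytotoxicity; on this read-out higher numbers stand for lower toxicity in this test and lower numbers for higher toxicity in this test:

Compound 1 `O=C(Nc1ncc(Cc2ccc(F)cc2)s1)C1CCCCC1` gives > 50000 nM in this assay; this is a limit of the assay and not a number.

Compound 2 `CCN(CC)C(=O)Nc1ncc(C(Oc2ccc3cc(Br)ccc3c2)c2ccc(Cl)cc2)s1` gives "not toxic" (no number reported) in this assay, a call reported without a number.

Compound 2 therefore stands without a single number in this assay. Among the measured compounds shown here, of the two values shown, one sits at the limit of > 50000 nM in this assay, at which 1 of the 2 values shown sits, and the other is the unquantified call for compound 2, so no step between measured compounds can be drawn.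

Compound 3 `O=S(=O)(Nc1ncc(C(Oc2ccc3cc(Br)ccc3c2)c2ccc(Cl)cc2)s1)c1ccc(Cl)nc1` differs from compound 2 by (6-chloropyridin-3-yl)sulfonyl in place of diethylcarbamoyl on a nitrogen on an aromatic ring. For the measured compounds named here, with no measured step to lean on, the expectation in this assay is for no shift beyond the scatter, compound 3 being read as non-toxic in the same way as compound 2. Compound 3 is expected to give 40000 nM, within a range from 10000 nM to 100000 nM, with a fair chance that only a limit is returned.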

Compound 3, half-maximal cytotoxic concentration: "not toxic" (no number reported)
The entry for compound 3 holds no number, and the estimate cannot be compared.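

In this assay, compound 2 and compound 3 both stand as unquantified calls, so no step can be read between them. Whether diethylcarbamoyl and (6-chloropyridin-3-yl)sulfonyl differ in cytotoxicity stays open, and the only other value shown is no number either: the limit of > 50000 nM in this assay, at which 1 of the 3 values shown sits.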